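Replacing a Ring-Bearing Amine with Dipropylamino on the Shared Core

This account rests on a few compounds, and the source may have more. Where it says the series, first, only, none or still open, it means among the compounds named here.

Of the compounds shown here, three built on one shared core have been tested in an assay on HEK293 cells for inhibition of Steryl-sulfatase (Homo sapiens), tested at 0.1 uM; a lower number here means a weaker effect, a higher number a stronger effect of the compound at the concentration tested. Compound 1 `NS(=O)(=O)Oc1ccc2c(c1)CN(C(=O)c1cccc(N3CCCCC3)c1)CC2` gives 1%, compound 2 `CCN(Cc1cccc(Br)c1)c1cccc(C(=O)N2CCc3ccc(OS(N)(=O)=O)cc3C2)c1` gives 20.9%, and compound 3 `NS(=O)(=O)Oc1ccc2c(c1)CN(C(=O)c1cccc(N3CCc4ccccc4C3)c1)CC2` gives 24.1%. Compound 3 carries the largest of the three numbers, but the gap a number 3.2 percentage points higher from compound 2 to compound 3 (within the scatter) means the two cannot be told apart, whereas the gap a number 23.1 percentage points higher from compound 1 to compound 3 (beyond the scatter) is clear.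

Compound 4 `CCCN(CCC)c1cccc(C(=O)N2CCc3ccc(OS(N)(=O)=O)cc3C2)c1` differs from compound 3 in one place: dipropylamino in place of 1,2,3,4-tetrahydroisoquinolin-2-yl on an aromatic carbon. Going by the values given here, two measured steps bear on this. The step of a number 23.1 percentage points higher from compound 1 to compound 3 (beyond the scatter) shows that 1,2,3,4-tetrahydroisoquinolin-2-yl gave a markedly higher inhibition than piperidin-1-yl, and the step of a number 19.9 percentage points higher from compound 1 to compound 2 (beyond the scatter) shows a similar rise for (3-bromobenzyl)(ethyl)amino. Among the compounds with values here, the group entering in compound 4 has no ring at all, and the only acyclic group measured so far, in compound 2, still carried a six-membered aromatic ring. Compound 1, carrying piperidin-1-yl, gives the lowest number of the three. A drop from compound 3 toward that level is therefore expected, and compound 4 is estimated at 8%, within 0% to 22%, which corresponds to an expected step of a number 16.1 percentage points lower from compound 3 to compound 4 (beyond the scatter).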

Compound 4, a percentage reported as inhibition, at one concentration (the size of the read-out at that concentration, not a potency): 8.3%
For compound 4 the middle estimate is 0.3 percentage points below the measured one; measured number inside the range.
By their numbers in this assay, from the lowest: compounds 1 and 4 (each within the scatter of the next); then compounds 2 and 3 (each within the scatter of the next).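

In this assay, the change to dipropylamino shows that an acyclic amine at this position does not by itself hold the higher level, with a number 15.8 percentage points lower from compound 3 to compound 4 (beyond the scatter) and a number 12.6 percentage points lower from compound 2 to compound 4 (beyond the scatter) both in the same direction, while a number 7.3 percentage points higher from compound 1 to compound 4 (within the scatter) leaves the group indistinguishable from piperidin-1-yl. Across these four compounds, the two groups carrying a six-membered aromatic ring, in compound 2 and compound 3, stand clear of the two without one, in compound 1 and compound 4, and none of the four goes against this, whether the amine is open-chain or ring-closed. Nothing available explains why these numbers differ.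

The compounds shown leave open whether the aromatic ring itself accounts for the difference, which a cyclohexylmethyl group in place of the 3-bromobenzyl group, or a plain benzyl group without the bromine, would help to separate. They also leave open whether a longer chain, such as dibutylamino, would stay at the level of compound 4 or move toward that of compound 3.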